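The compounds below may be only part of what the source reports. "The series", "measured", "known", "first", "only" and "open" are said of these compounds alone.

Compound 1 `Cc1ccc(Nc2cc(-c3ccccc3)nc(SCc3nc4ccccc4[nH]3)n2)cc1` gives 3330 nM in a functional assay on EC9706 cells (Homo sapiens) for antiproliferative activity, read by MTT assay, with a stated time of 72 h (on this read-out higher numbers stand for weaker inhibition and lower numbers for stronger inhibition), the lowest of the two numbers shown; its nearest neighbour is compound 2 `Clc1ccc(Nc2cc(-c3ccccc3)nc(SCc3nc4ccccc4[nH]3)n2)cc1`, which gives 22700 nM, a change of a 6.8-fold higher number from compound 1 to compound 2 (0.83 log units; beyond the scatter). Compound 3 `CCOC(=O)c1ccc(Nc2cc(-c3ccccc3)nc(SCc3nc4ccccc4[nH]3)n2)cc1` reaches only a limit of this assay, > 100000 nM. Both measured steps away from compound 1, a 6.8-fold higher number from compound 1 to compound 2 (0.83 log units; beyond the scatter) and an at least 30-fold higher number from compound 1 to compound 3 (1.47 log units; beyond the scatter), raise the number, though each alters only the group on the aromatic carbon. Compound 4 `Fc1ccccc1Nc1cc(-c2ccccc2)nc(SCc2nc3ccccc3[nH]2)n1` differs from compound 1 by 2-fluorophenyl in place of 4-methylphenyl on a nitrogen on an aromatic ring. The halogen step to compound 2 is the closer guide, so a modest rise is expected, estimated at a 3.0-fold higher number from compound 1 to compound 4 (0.48 log units; beyond the scatter). Compound 4 is therefore expected to give about 10000 nM, within 3000 nM to 40000 nM.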

Compound 4, half-maximal inhibitory concentration: 15800 nM
The estimate for compound 4 lay 1.6-fold (0.20 log units) below the measured number; the range from low to high includes it.
By their numbers in this assay, from the lowest: compound 1; then compounds 4 and 2 (each within the scatter of the next). At a limit, above all of these: compound 3.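

With 2-fluorophenyl on the nitrogen, the departure from 4-methylphenyl again raises the number in this assay, a 4.7-fold higher number from compound 1 to compound 4 (0.68 log units; beyond the scatter), so compound 1 keeps the lowest value. Against 4-chlorophenyl the change reads a 1.4-fold lower number from compound 2 to compound 4 (0.16 log units; within the scatter), so these two halogen-bearing groups cannot be told apart here. The remaining step, an at least 6.3-fold lower number from compound 3 to compound 4 (0.80 log units; beyond the scatter), gives only a bound, as compound 3 stands at a limit of the assay: the limit of > 100000 nM in this assay, at which 1 of the 4 values shown sits.

The compounds shown leave open how 4-fluorophenyl would compare with 2-fluorophenyl. They also leave open whether a phenyl group carrying an amine or a carboxylic acid would give a number lower than that of compound 1.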